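A Nitrile Replaces Hydrogen on a Poorly Soluble Core

This account rests on a few compounds, and the source may have more. Where it says the series, first, only, none or still open, it means among the compounds named here.

Compound 1 `C[C@H](Oc1ccc(S(C)(=O)=O)cc1C(=O)N1Cc2ccccc2C1)C(F)(F)F` has been measured in a physicochemical assay for solubility; a lower number here means a less soluble compound, a higher number a more soluble compound. In this assay compound 1 gives < 1 ug/mL, which is a limit of the assay and not a number. Going by the values given here, compound 2 `C[C@H](Oc1ccc(S(C)(=O)=O)cc1C(=O)N1Cc2ccc(N3CCCC3)cc2C1)C(F)(F)F` is the only other compound measured. In this assay compound 2 gives < 1 ug/mL, again a limit. The step that the two limits leave unreadable from compound 1 to compound 2 therefore cannot be read, and the whole of the evidence is summed up by the limit of < 1 ug/mL in this assay, at which 2 of the 2 values shown sit. Compound 3 `C[C@H](Oc1ccc(S(C)(=O)=O)cc1C(=O)N1Cc2cccc(C#N)c2C1)C(F)(F)F` has not yet been measured in this assay. It differs from compound 1 as follows: cyano in place of hydrogen on an aromatic carbon. No measured step bears on this change, as the one step shown is unreadable. The expectation is therefore a step that the limit leaves unreadable from compound 1 to compound 3 that stays within the scatter, with the result most likely again reported as a limit. Compound 3 is estimated at 0.7 ug/mL, with a range from 0.2 ug/mL to 3 ug/mL.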

Compound 3, solubility: 259 ug/mL
Beside the measured number, compound 3's estimate is 370-fold (2.57 log units) below it, and the stated range ends below it.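

In this assay, cyano in place of hydrogen on an aromatic carbon, ortho to a fused ring and meta to a fused ring, gives an at least 250-fold higher number from compound 1 to compound 3 (2.41 log units; beyond the scatter). Compound 1 gives < 1 ug/mL, which is a limit and not a number. The one earlier step cannot be read, so this is the first readable change on the shared core, and compound 3 alone stands clear of the limit: the limit of < 1 ug/mL in this assay, at which 2 of the 3 values shown sit.

The compounds shown leave open whether a fluorine atom, a methoxy group or a carboxamide on this same aromatic carbon would give a step of similar size, and whether cyano on another carbon of that ring would do so. They also leave open what cyano would give on a core that also carries a pyrrolidin-1-yl group.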